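The source may hold more compounds than are shown below. What is called first, only, known or untested is meant among the compounds shown, and "the series" means these compounds.

Compound 3 `CC(C)(C)c1ccc(C(=O)N2CCC3(CC2)C(=O)N(CC(=O)N2CCC(CCO)CC2)CN3c2ccccc2)cc1` gives 2600 nM in an assay on HEK293 cells for displacement of a labelled ligand from NPC1-like intracellular cholesterol transporter 1 (Homo sapiens) (a lower number here means a stronger inhibitor, a higher number a weaker inhibitor), the lowest of the three numbers in hand. Compound 2 `CC(C)(C)c1ccc(C(=O)N2CCC3(CC2)C(=O)N(CC(=O)NCCCN)CN3c2ccccc2)cc1` gives 4200 nM in this assay, and compound 1 `CC(C)(C)c1ccc(C(=O)N2CCC3(CC2)C(=O)N(CC(=O)NCCC(=O)O)CN3c2ccccc2)cc1` gives 11400 nM; the gap from compound 3 to compound 2 lies within the scatter, while a 4.4-fold lower number from compound 1 to compound 3 (0.64 log units; beyond the scatter) and a 2.7-fold lower number from compound 1 to compound 2 (0.43 log units; beyond the scatter) stand beyond it.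

Compound 4 `CC(C)(C)OC(=O)NCCCNC(=O)CN1CN(c2ccccc2)C2(CCN(C(=O)c3ccc(C(C)(C)C)cc3)CC2)C1=O` differs from compound 3 in one place: (3-((tert-butoxycarbonyl)amino)propyl)amino in place of 4-(2-hydroxyethyl)piperidin-1-yl on a carbonyl carbon. Among the compounds with values here, the only measured step that bears on this is a 1.6-fold lower number from compound 2 to compound 3 (0.21 log units; within the scatter), which reverses part of the same change; the effect of the tert-butoxycarbonyl cap on the chain has no measured precedent. A step of about a 1.9-fold higher number from compound 3 to compound 4 (0.28 log units; within the scatter) is therefore expected, upward and near the edge of the scatter, and compound 4 is estimated at 5000 nM with a range of 2000 nM to 15000 nM.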

Compound 4, half-maximal inhibitory concentration: 4500 nM
Estimate against measurement, compound 4: 1.1-fold (0.05 log units) above, within the range that was stated.
By their numbers in this assay, from the lowest: compounds 3, 2 and 4 (each within the scatter of the next); then compound 1.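

In this assay, the tert-butoxycarbonyl cap on the amine nitrogen of the aminopropyl chain does not separate the capped chain from the free amine (a 1.1-fold higher number from compound 2 to compound 4 (0.03 log units; within the scatter)), so this position accepts the cap. The capped chain also cannot be told apart from 4-(2-hydroxyethyl)piperidin-1-yl (a 1.7-fold higher number from compound 3 to compound 4 (0.24 log units; within the scatter)), and only the carboxy compound stands apart (a 2.5-fold lower number from compound 1 to compound 4 (0.40 log units; beyond the scatter)). No measured evidence accounts for these numbers.

Open, going by these compounds, is whether a longer chain carrying the same cap, or an acetyl group on the amine nitrogen, would stand apart from compound 3 beyond the scatter.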